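A few compounds are considered here, and "the series" means these few. Any claim that something is new, unique, unknown or untested is made for them only; others in the source may bear on it.

Measured in a functional assay for inhibition, with Homo sapiens as the target; on this read-out higher numbers stand for weaker inhibition and lower numbers for stronger inhibition:
- compound 1 `CN(C)c1cccc(Nc2nccc(-c3cccnc3)n2)c1`: 1800 nM
- compound 2 `c1cc(Nc2nccc(-c3cccnc3)n2)cc(OCCn2ccnc2)c1`: 100 nM

Among the compounds with values here, compound 1 has the higher number of the two measured compounds, and compound 2 is its only neighbour. Compound 3 `CN(C)c1cccc(Nc2nccc(-c3cccs3)n2)c1` keeps the dimethylamino group of compound 1 and carries thiophen-2-yl in place of pyridin-3-yl on an aromatic carbon.

One measured step exists, an 18-fold lower number from compound 1 to compound 2 (1.26 log units; beyond the scatter). It is large, but it concerns the replacement of dimethylamino and leaves pyridin-3-yl untouched, so it gives no direct guide to this change. Within the data shown here, no measured compound carries thiophen-2-yl. No step beyond the scatter is therefore expected in this assay, and the data favour no direction, so the range stays wide on both sides.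

The estimated step is a 1.1-fold higher number from compound 1 to compound 3 (0.05 log units; within the scatter). For compound 3 the expected value is 2000 nM, with an estimated range of 600 nM to 7000 nM.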

Compound 3, half-maximal inhibitory concentration: 2400 nM
Beside the measured number, compound 3's estimate is 1.2-fold (0.08 log units) below it; the measured number falls inside the stated range.
By their numbers in this assay, from the lowest: compound 2; then compounds 1 and 3 (each within the scatter of the next).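

The position held by pyridin-3-yl now has its first direct reading: in this assay thiophen-2-yl in its place gives a 1.3-fold higher number from compound 1 to compound 3 (0.12 log units; within the scatter), so this assay does not separate the two rings. With dimethylamino kept, a five-membered aromatic ring with sulfur as its hetero atom serves here as well as a six-membered aromatic ring with nitrogen as its hetero atom, and the nitrogen of pyridin-3-yl is not required for a number of this order. Nothing at hand explains why the two rings read alike.

On these data alone, whether the same swap stays within the scatter alongside the 2-(1H-imidazol-1-yl)ethoxy group of compound 2 remains open. Also open, as far as these compounds go, is how plain phenyl or furan-2-yl would read at this position, and whether any ring here can move the number as far as the change at the dimethylamino position did.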